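The source may report more compounds than this note shows. Statements on the series, on what has been measured and on what is new or still open speak of the compounds shown alone.

Four compounds share one core and differ only in the chain that ends in hydroxycarbamoyl: compound 1 (`CC(C)CCc1c(OCCCCCC(=O)NO)ccc2ccc(=O)oc12`), compound 2 (`CC(C)CCc1c(OCCCCCCCC(=O)NO)ccc2ccc(=O)oc12`), compound 3 (`CC(C)CCc1c(OCCCCC(=O)NO)ccc2ccc(=O)oc12`) and compound 4 (`CC(C)CCc1c(OCCCCCCC(=O)NO)ccc2ccc(=O)oc12`). In a functional assay on PC-3 cells (Homo sapiens) for antiproliferative activity, read by sulforhodamine B assay, with a stated time of 48 h (on this read-out lower numbers stand for stronger inhibition of growth and higher numbers for weaker inhibition of growth), compound 1 gives 740 nM, compound 2 gives 1730 nM and compound 3 gives 1940 nM. Compound 3 therefore stands at the high end alongside compound 2: the data show a 1.1-fold higher number from compound 2 to compound 3 (0.05 log units; within the scatter), and also a 2.6-fold higher number from compound 1 to compound 3 (0.42 log units; beyond the scatter).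

The change to compound 4 is 2-(hydroxycarbamoyl)ethyl in place of hydroxycarbamoyl on a saturated chain carbon, four bonds along the chain from an oxygen on an aromatic ring: 2-(hydroxycarbamoyl)ethyl in place of hydroxycarbamoyl, on a saturated chain carbon, four bonds along the chain from an oxygen on an aromatic ring. This gives compound 4 a chain longer than that of compound 1 and shorter than that of compound 2. The two steps that bear most directly are a 2.6-fold higher number from compound 1 to compound 3 (0.42 log units; beyond the scatter) and a 2.3-fold higher number from compound 1 to compound 2 (0.37 log units; beyond the scatter), both modest, so a small move towards a lower number is expected in this assay. The expected step is a 1.8-fold lower number from compound 3 to compound 4 (0.25 log units; within the scatter), which may not clear the usual scatter. The estimate for compound 4 is 1100 nM, with an expected range from 500 nM to 2300 nM.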

Compound 4, concentration for 50% growth inhibition: 520 nM
Compound 4: the middle estimate sits 2.1-fold (0.33 log units) above what was measured; the range from low to high includes it.
By their numbers in this assay, from the lowest: compounds 4 and 1 (each within the scatter of the next); then compounds 2 and 3 (each within the scatter of the next).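

In this assay, compound 4 stands apart from the shortest and longest chains, with a 3.7-fold lower number from compound 3 to compound 4 (0.57 log units; beyond the scatter) and a 3.3-fold lower number from compound 2 to compound 4 (0.52 log units; beyond the scatter), while a 1.4-fold lower number from compound 1 to compound 4 (0.15 log units; within the scatter) shows no real difference. The low numbers therefore belong to the two middle chains, and adding chain length can raise or lower the number depending on the starting chain: the same change on two cores in this assay, a 2.3-fold higher number (0.37 log units; beyond the scatter) from compound 1 to compound 2 and a 3.7-fold lower number (0.57 log units; beyond the scatter) from compound 3 to compound 4, 8.7-fold (0.94 log units) apart, beyond the scatter of two such steps. Shortening the chain likewise goes both ways: the same change on two cores in this assay, a 2.6-fold higher number (0.42 log units; beyond the scatter) from compound 1 to compound 3 and a 3.3-fold lower number (0.52 log units; beyond the scatter) from compound 2 to compound 4, 8.7-fold (0.94 log units) apart, beyond the scatter of two such steps.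

The compounds shown leave open how a chain shorter than that of compound 3, or longer than that of compound 2, would behave. They also leave open what a carboxylic acid in place of hydroxycarbamoyl would do on these chains.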